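Series notes: from compound 3 to compound 4

This account rests on a few compounds, and the source may have more. Where it says the series, first, only, none or still open, it means among the compounds named here.

Compound 1, `COc1cc(N)c(Cl)cc1NC(=O)C1CCN(CC2CC2)CC1`: in a functional assay on the whole organism for antagonist activity, with Mus musculus as the target (on this read-out higher numbers stand for an effect only at larger amounts of compound and lower numbers for an effect already at smaller amounts), compound 1 gives > 10 mg/kg, a limit of the assay.
Compound 2, `COc1cc(N)c(Cl)cc1NC(=O)C1CCN(Cc2ccccc2Cl)CC1`: in this assay compound 2 gives > 4 mg/kg, a limit of the assay.
Compound 3, `CCCCN1CCC(C(=O)Nc2cc(Cl)c(N)cc2OC)CC1`: in this assay compound 3 gives > 10 mg/kg, a limit of the assay.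

Compound 3 stands nowhere definite on these numbers: its value is a limit, and the two further values shown are limits as well. The three measured steps, a step that the two limits leave unreadable from compound 1 to compound 2, a step that the two limits leave unreadable from compound 1 to compound 3 and a step that the two limits leave unreadable from compound 2 to compound 3, are all of unreadable size; each joins two limits, and no order among the three measured compounds can be drawn from them.

Compound 4, `COc1cc(N)c(Cl)cc1NC(=O)C1CCN(Cc2ccc([N+](=O)[O-])cc2)CC1`, differs from compound 3 by 4-nitrophenyl in place of propyl on a saturated chain carbon bound to an amine nitrogen in a ring. For the measured compounds named here, the steps that bear on this change are the three exchanges of the group on the same carbon, and none of them is readable. Going by the values given here, two of the three values sit at the limit of > 10 mg/kg in this assay, at which 2 of the 3 values shown sit, and one sits at the limit of > 4 mg/kg in this assay, at which 1 of the 3 values shown sits, so there is no measured step to carry over. What is expected for compound 4 in this assay is therefore no step beyond the scatter: a number no higher from compound 3 to compound 4 (the limit leaves the size open). The estimate for compound 4 in this assay is 10 mg/kg, between 3 mg/kg and 40 mg/kg, with a real chance that the assay again returns only a limit.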

Compound 4, dose for half-maximal effect: > 4 mg/kg
Compound 4: no number, only a limit (the forecaster's own chance of this, stated with the estimate: 70%); the middle value is on the limit's open side.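

In this assay compound 4 gives > 4 mg/kg, a limit of the assay. Compound 1, compound 2 and compound 3 also carry only limits, so none of the steps to compound 4 can be read. The compounds shown leave open how cyclopropyl, propyl, 2-chlorophenyl and 4-nitrophenyl rank against one another in this assay, and whether any of them gives a real number there.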